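The compounds below may be only part of what the source reports. "The series", "measured", "known", "first", "only" and "open" are said of these compounds alone.

In a functional assay on PANC-1 cells (Homo sapiens), read by microscopy, crystal violet staining and transwell migration, with a stated time of 18 h, in the presence of a further agent that is not named here (on this read-out lower numbers stand for stronger inhibition and higher numbers for weaker inhibition), compound 3 `CCOc1ccc(-c2nc(CC)nn2-c2cccc(C(=O)NCCCCc3ccccc3)c2)cc1` gives 16800 nM, the higher of the two actual numbers, while compound 1 `COc1ccc(-c2nc(C)nn2-c2cccc(C(=O)NCCCCc3ccc(Br)cc3)c2)cc1` gives 3020 nM, a gap beyond the usual scatter. Compound 2 `COc1ccc(-c2ncnn2-c2cccc(C(=O)NCCCCc3ccccc3)c2)cc1` reports only a limit of the assay, > 20000 nM. The next compound, compound 4 `CCc1nc(-c2ncc(OC)cn2)n(-c2cccc(C(=O)NCCCCc3ccccc3)c2)n1`, keeps the rest of compound 3 but carries 5-methoxypyrimidin-2-yl in place of 4-ethoxyphenyl on an aromatic carbon, and the counted difference is 5-methoxypyrimidin-2-yl in place of 4-ethoxyphenyl on an aromatic carbon. Going by the values given here, no measured pair here tests such a swap, so no change beyond the scatter is expected in this assay. The expected step is a 1.1-fold higher number from compound 3 to compound 4 (0.03 log units; within the scatter). For compound 4, the estimated value is 18000 nM, with an expected range from 8000 nM to 40000 nM.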

Compound 4, half-maximal inhibitory concentration: 110 nM
Beside the measured number, compound 4's estimate is 160-fold (2.21 log units) above it; the measured number lies below the stated range.
By their numbers in this assay, from the lowest: compound 4; then compound 1; then compound 3. At a limit, above all of these: compound 2.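

In this assay, the group on this aromatic carbon, between two ring nitrogen atoms, has a very large effect on the read-out: placing 5-methoxypyrimidin-2-yl where 4-ethoxyphenyl stood gives a 150-fold lower number from compound 3 to compound 4 (2.18 log units; beyond the scatter), with the rest of the molecule unchanged. The earlier compounds shown here offered no single-place comparison at this position. Nothing shown explains why the change has such a large effect.

The swap changes the ring atoms and the alkoxy group together, so their contributions remain unseparated. A 5-ethoxypyrimidin-2-yl group or a methoxy-bearing pyridine ring at this position would help tell them apart.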